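The compounds below may be only part of what the source reports. "The series", "measured", "known", "first", "only" and "open" are said of these compounds alone.

Compound 2 `COc1ccc(-c2ccc([C@@H](c3ccccc3)[C@@](O)(CCN(C)C)c3cccc4ccccc34)c(OC)n2)cc1` was tested in a toxicity assay on Vero cells (Chlorocebus sabaeus) for cytotoxicity; on this read-out higher numbers stand for lower toxicity in this test and lower numbers for higher toxicity in this test. In this assay compound 2 reached only the limit of > 50 ug/mL. Compound 1 `COc1nc(-c2ccc(Br)cc2)ccc1[C@@H](c1ccccc1)[C@@](O)(CCN(C)C)c1cccc2ccccc12` likewise gave only the limit of > 50 ug/mL. Compound 3 `COc1ncc(-c2ccccc2)cc1[C@@H](c1ccccc1)[C@@](O)(CCN(C)C)c1cccc(F)c1F` also gave only the limit of > 50 ug/mL. For the measured compounds named here, all three results sit at the limit of > 50 ug/mL in this assay, at which 3 of the 3 values shown sit, which leaves the one comparable step, a step that the two limits leave unreadable from compound 1 to compound 2, unreadable in size. Compound 4 `COc1nc(-c2ccc(Cl)cc2)ccc1[C@@H](c1ccccc1)[C@@](O)(CCN(C)C)c1cccc2ccccc12` differs from compound 2 by chloro in place of methoxy on an aromatic carbon. Going by the values given here, no measured step with a readable size bears on this change, since the only related step is hidden by the limits. The expected step is therefore a step that the limit leaves unreadable from compound 2 to compound 4, none beyond the scatter. Compound 4 is estimated to lie at 60 ug/mL, within a range from 35 ug/mL to 110 ug/mL, most likely again reported only as a limit.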

Compound 4, half-maximal cytotoxic concentration: > 50 ug/mL
Compound 4 gave a limit, no number; the forecaster's own chance of this, stated with the estimate: 85%; the middle value is on the limit's open side.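

Compound 4, like compound 1 and compound 2, gave only a limit, so no step among them can be read: the limit of > 50 ug/mL in this assay, at which 4 of the 4 values shown sit.

The compounds shown leave open how far any of them lies beyond that limit, and whether exchanging methoxy, bromo and chloro changes the read-out at all.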